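One dimethylaminoethyl arm returns to a benzyl-bearing core

The source may hold more compounds than are shown below. What is called first, only, known or untested is meant among the compounds shown, and "the series" means these compounds.

Compound 3 `CCCN(Cc1ccccc1)c1ccc(C(=O)N2CCc3ccc(OS(N)(=O)=O)cc3C2)cc1` gives 94.3% in an assay on HEK293 cells for inhibition of Steryl-sulfatase (Homo sapiens), tested at 1 uM (a higher number here means a stronger effect of the compound at the concentration tested, a lower number a weaker effect), the second highest of three numbers. Compound 2 `NS(=O)(=O)Oc1ccc2c(c1)CN(C(=O)c1ccc(N(Cc3ccccc3)Cc3ccco3)cc1)CC2` gives 98.2%, and a number 3.9 percentage points lower from compound 2 to compound 3 (within the scatter). Compound 1 `CN(C)CCN(CCN(C)C)c1ccc(C(=O)N2CCc3ccc(OS(N)(=O)=O)cc3C2)cc1` gives 15.9%, and a number 78.4 percentage points higher from compound 1 to compound 3 (beyond the scatter).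

Compound 4 `CN(C)CCN(Cc1ccccc1)c1ccc(C(=O)N2CCc3ccc(OS(N)(=O)=O)cc3C2)cc1` differs from compound 3 in one place: dimethylamino in place of methyl on a saturated chain carbon, two bonds along the chain from a nitrogen on an aromatic ring. The step from compound 1 to compound 3 bears on this, since compound 1 carries two such dimethylamino-bearing chains and no benzyl, whereas compound 4 keeps the benzyl and gains only one such chain. A drop seems likely, but smaller than the full loss seen in compound 1. The expected step is a number 22.3 percentage points lower from compound 3 to compound 4 (beyond the scatter). Compound 4 is therefore estimated at 72%, within 40% to 95%.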

Compound 4, a percentage reported as inhibition, at one concentration (the size of the read-out at that concentration, not a potency): 57.8%
Beside the measured number, compound 4's estimate is 14.2 percentage points above it, and the stated range covers the measured number.
By their numbers in this assay, from the lowest: compound 1; then compound 4; then compounds 3 and 2 (each within the scatter of the next).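

The earlier compounds shown here could not show whether the loss required two dimethylamino-bearing chains. In this assay, a single 2-(dimethylamino)ethyl arm already brings a large drop, whether set against propyl (a number 36.5 percentage points lower from compound 3 to compound 4 (beyond the scatter)) or against the furan-2-yl-bearing arm (a number 40.4 percentage points lower from compound 2 to compound 4 (beyond the scatter)). The loss with one such arm is only partial, as the benzyl on the other arm shows (a number 41.9 percentage points higher from compound 1 to compound 4 (beyond the scatter)). Nothing available explains these drops. Still open, going by these compounds, is how a 2-methoxyethyl arm, with an ether oxygen in place of the amine, would compare, and how a longer chain ending in dimethylamino would behave.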